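The source may hold more compounds than are shown below. What is called first, only, known or untested is meant among the compounds shown, and "the series" means these compounds.

Measured compounds in an ADME assay on microsomes from liver (Homo sapiens) for metabolic stability, read by LC-MS, tested at 1 uM; a higher number here means faster removal of the compound, a lower number slower removal:
Compound 1 `NCCCOc1ccc([C@H]2CC[C@]3(CC2)OOC2(O3)C3CC4CC(C3)CC2C4)cc1` gives < 7 mL.min-1.g-1 in this assay, which is a limit of the assay rather than a number.
Compound 2 `CC(C)(O)CNCCCOc1ccc([C@H]2CC[C@]3(CC2)OOC2(O3)C3CC4CC(C3)CC2C4)cc1` gives 8 mL.min-1.g-1 in this assay.

Compound 1 stands at the limit of this assay (the limit of < 7 mL.min-1.g-1 in this assay, at which 1 of the 2 values shown sits), so only a limit is known for it. Within the data shown here, the one measured step, an at least 1.1-fold higher number from compound 1 to compound 2 (0.05 log units; that floor lies within the scatter), has a floor within the scatter, so the two measured compounds cannot be ordered in this assay.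

Compound 3 `CC(C)(CN)Oc1ccc([C@H]2CC[C@]3(CC2)OOC2(O3)C3CC4CC(C3)CC2C4)cc1` has not yet been measured in this assay. It differs from compound 1 as 1-(aminomethyl)-1-methylethyl in place of 3-aminopropyl on an oxygen on an aromatic ring. Among the measured compounds shown here, the only measured step alters the amine nitrogen, not the ether end of the chain, so no measured step bears directly on this change; both measured compounds sit at or close to the limit, and no shift beyond the scatter is anticipated. Compound 3 is therefore expected to show a number no lower from compound 1 to compound 3 (the limit leaves the size open). Compound 3 is estimated at 7 mL.min-1.g-1 in this assay, with a range from 4 mL.min-1.g-1 to 14 mL.min-1.g-1, and a fair chance that the assay again reports only a limit.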

Compound 3, intrinsic clearance in microsomes: < 7 mL.min-1.g-1
Compound 3: no number, only a limit; the forecaster's own chance of this, stated with the estimate: 50%; the middle value lies on the limit itself.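

Compound 3, with 1-(aminomethyl)-1-methylethyl in place of 3-aminopropyl on an oxygen on an aromatic ring, gives in this assay a limit of the assay and not a number, so the first reading at the ether end of the chain shows that this change does not bring the value off the limit, which now holds most of the compounds shown: the limit of < 7 mL.min-1.g-1 in this assay, at which 2 of the 3 values shown sit.

Going by these compounds, the step between compound 1 and compound 3 cannot be read, as both values are limits, so the size of this change remains unknown. The one readable new step is an at least 1.1-fold lower number from compound 2 to compound 3 (0.05 log units; that floor lies within the scatter), and it gives no order among these compounds.

On these data alone, what stays open is whether compound 1 and compound 3 differ at all under the limit, and whether a 2-hydroxy-2-methylpropyl group on the amine nitrogen of compound 3 would behave as it does on compound 1. Also open, as far as these compounds go, is whether a carboxylic acid or a morpholine in place of the amine, or a longer chain on the same oxygen, would give a readable number in this assay.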